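Second nitro group on the aryl ring of compound 2

The source may report more compounds than this note shows. Statements on the series, on what has been measured and on what is new or still open speak of the compounds shown alone.

Of the compounds shown here, three have been tested so far. Compound 1 `O=c1c2ccccc2[se]n1-c1nnc(-c2ccc(Br)cc2)s1` gives 39100 nM in a functional assay on A549 cells (Homo sapiens) for antiproliferative activity, read by CCK-8 assay, with a stated time of 48 h (on this read-out higher numbers stand for weaker inhibition and lower numbers for stronger inhibition), compound 2 `O=c1c2ccccc2[se]n1-c1nnc(-c2cccc([N+](=O)[O-])c2)s1` gives 16100 nM, and compound 3 `COc1cc(-c2nnc(-n3[se]c4ccccc4c3=O)s2)cc(OC)c1OC` gives 3240 nM. On these numbers compound 2 stands second highest of the three: its nearest neighbour is compound 1, whose value is higher by more than the scatter, and its furthest is compound 3, whose value is lower by well more than the scatter. Within the data shown here, no pair among the measured compounds differs in a single place, so no measured single-change step is available to lean on.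

Compound 4 `O=c1c2ccccc2[se]n1-c1nnc(-c2cc([N+](=O)[O-])cc([N+](=O)[O-])c2)s1` has not yet been measured. It differs from compound 2 by nitro in place of hydrogen on an aromatic carbon. Among the measured compounds shown here, since nothing measured here shows what a second nitro group does on this aryl ring, the direction of the step is open; the only anchor is the value of compound 2, 16100 nM, from which a step of modest size in either direction, or none beyond the scatter, is plausible. Compound 4 is therefore expected to land near compound 2, with an estimated step of a 1.3-fold lower number from compound 2 to compound 4 (0.13 log units; within the scatter). The estimate for compound 4 is 12000 nM, with a range from 4000 nM to 40000 nM.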

Compound 4, half-maximal inhibitory concentration: 17900 nM
Compound 4: middle estimate off by 1.5-fold (0.17 log units), on the low side; the range from low to high includes it.
By their numbers in this assay, from the lowest: compound 3; then compounds 2 and 4 (each within the scatter of the next); then compound 1.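

In this assay, the series now has its first reading of a single change: a 1.1-fold higher number from compound 2 to compound 4 (0.05 log units; within the scatter), for nitro in place of hydrogen on an aromatic carbon. Among these compounds, at this place, meta to a large group and meta to a nitro group, the two values cannot be told apart, so the entering group with its 3 heavy atoms leaves the read-out within the scatter in this one pair, something the earlier compounds, none of which differed in a single place, could not show. No measurement of any property accompanies this step, so nothing here accounts for the result.

On these data alone, whether an amine or a carboxylic acid in place of the same hydrogen on compound 2 would also stay within the scatter remains open, and so does the outcome with a longer chain there. Also open, as far as these compounds go, is whether nitro in place of hydrogen would give a similar step on the aryl rings of compound 1 and compound 3, since this single pair speaks only for the aryl ring of compound 2.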